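This account rests on a few compounds, and the source may have more. Where it says the series, first, only, none or still open, it means among the compounds named here.

Measured compounds:
- compound 1 `CC(C)COc1ccc2oc(/C=C/[S+](C)[O-])cc(=O)c2c1` gives 1100 nM in a functional assay on A549 cells (Homo sapiens) for cytotoxicity, with a stated time of 48 h; on this read-out lower numbers stand for stronger inhibition and higher numbers for weaker inhibition
- compound 2 `C[S+]([O-])/C=C/c1cc(=O)c2cc(F)ccc2o1` gives 2100 nM in this assay
- compound 3 `COc1ccc2oc(/C=C/[S+](C)[O-])cc(=O)c2c1` gives 1600 nM in this assay

On these three numbers compound 1 has the lowest value, but the steps to compound 3 a 1.5-fold higher number from compound 1 to compound 3 (0.16 log units; within the scatter) and to compound 2 a 1.9-fold higher number from compound 1 to compound 2 (0.28 log units; within the scatter) both stay within the scatter, so no order among the three can be claimed. The step from compound 2 to compound 3 a 1.3-fold lower number from compound 2 to compound 3 (0.12 log units; within the scatter) is likewise within the scatter.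

Compound 4 `CC(C)Oc1ccc2oc(/C=C/[S+](C)[O-])cc(=O)c2c1` differs from compound 1 in one place: isopropyl in place of isobutyl on an oxygen on an aromatic ring. Within the data shown here, the step that bears on this is the one from compound 1 to compound 3, where hydrogen replaced isopropyl on the saturated chain carbon bound to the oxygen on the aromatic ring, and it moved the number only within the scatter a 1.5-fold higher number from compound 1 to compound 3 (0.16 log units; within the scatter). Shortening the chain on that oxygen by one carbon is a smaller change than that one, so no step beyond the scatter is expected in this assay. Compound 4 is therefore expected to give 1300 nM with a range of 600 nM to 2800 nM, an expected step of a 1.2-fold higher number from compound 1 to compound 4 (0.07 log units; within the scatter).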

Compound 4, half-maximal inhibitory concentration: 1500 nM
The estimate for compound 4 lay 1.2-fold (0.06 log units) below the measured number; measured number inside the range.
By their numbers in this assay, from the lowest: compounds 1, 4, 3 and 2 (each within the scatter of the next).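

On the oxygen on the aromatic ring, isopropyl in place of isobutyl stays within the scatter (a 1.4-fold higher number from compound 1 to compound 4 (0.13 log units; within the scatter)), and so does isopropyl in place of methyl (a 1.1-fold lower number from compound 3 to compound 4 (0.03 log units; within the scatter)), so a third chain on this oxygen adds no readable difference. Isopropoxy in place of fluoro on the aromatic carbon also stays within the scatter (a 1.4-fold lower number from compound 2 to compound 4 (0.15 log units; within the scatter)), so in this assay no order can be claimed among the four groups at this place. No measurement shown bears on why these groups read alike.

Going by these compounds, it remains open whether a longer chain, an amine or a carboxylic acid at this place would move the number beyond the scatter. The compounds shown also leave open whether changes elsewhere on the shared core would do so.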